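Compound 1 Loses Its Methoxy

A few compounds are considered here, and "the series" means these few. Any claim that something is new, unique, unknown or untested is made for them only; others in the source may bear on it.

In a functional assay on B16-F10 cells (Mus musculus) for antiproliferative activity, read by MTT assay, with a stated time of 48 h (a higher number here means a weaker inhibitor, a lower number a stronger inhibitor), compound 1 `COc1ccc(/C=C/C(=O)Nc2cc(-c3ccc(Br)cc3)[nH]n2)cc1` gives 770 nM and compound 2 `O=C(/C=C/c1ccc([N+](=O)[O-])cc1)Nc1cc(-c2ccccc2)[nH]n1` gives 720 nM as its number, so the two sit within the scatter of each other. The change hydrogen in place of methoxy on an aromatic carbon turns 4-methoxyphenyl to phenyl, giving compound 3 `O=C(/C=C/c1ccccc1)Nc1cc(-c2ccc(Br)cc2)[nH]n1` with hydrogen in place of methoxy on an aromatic carbon. Going by the values given here, no measured pair shows this change alone, so no step beyond the scatter is expected in this assay in either direction. The estimated step of a 1.0-fold higher number from compound 1 to compound 3 (0.02 log units; within the scatter) stays within that scatter. Compound 3 is expected at 800 nM with an estimated range from 350 nM to 1800 nM in this measurement.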

Compound 3, half-maximal inhibitory concentration: 1270 nM
The estimate for compound 3 lay 1.6-fold (0.20 log units) below the measured number; the measured number falls inside the stated range.
By their numbers in this assay, from the lowest: compounds 2, 1 and 3 (each within the scatter of the next).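

Going by these compounds alone, replacing methoxy with hydrogen gives the first direct reading of this change: in this assay it gives a 1.6-fold higher number from compound 1 to compound 3 (0.22 log units; within the scatter). At this place, para to a large group, the assay therefore does not separate methoxy from hydrogen, and compound 3 keeps a number within the scatter of compound 1 without the methoxy. Nothing available bears on the reason for this step.

From the compounds shown here alone, whether an amine, a hydroxyl or a longer chain such as butoxy at this place would move the number beyond the scatter remains open. So does whether the same step would hold if the bromine of compound 3 gave way to hydrogen.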